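This account rests on a few compounds, and the source may have more. Where it says the series, first, only, none or still open, it means among the compounds named here.

Compound 1 `O=C(CSc1nc(Nc2ccccc2)c2ccccc2n1)Nc1cccc(F)c1` was tested in a functional assay on MGC-803 cells (Homo sapiens) for inhibition, read by MTT assay, with a stated time of 72 h (on this read-out higher numbers stand for weaker inhibition and lower numbers for stronger inhibition), where compound 1 gives 12700 nM. Among the three measured compounds, compound 1 has the second highest number: its nearest neighbour is compound 3 `C=CC(=O)Nc1cccc(NC(=O)CSc2nc(Nc3ccccc3)c3ccccc3n2)c1`, which gives 7310 nM, and the furthest is compound 2 `O=C(CSc1nc(Nc2ccccc2)c2ccccc2n1)Nc1cccc([N+](=O)[O-])c1`, which gives 28100 nM. Compound 4 `O=C(CSc1nc(Nc2ccccc2)c2ccccc2n1)Nc1ccc(Cl)cc1` has not yet been measured in this assay. It differs from compound 1 by 4-chlorophenyl in place of 3-fluorophenyl on an amide-type nitrogen. Within the data shown here, none of the measured steps exchanges one halogen for another, but three of them alter the same ring of the shared core: a 2.2-fold higher number from compound 1 to compound 2 (0.34 log units; beyond the scatter), a 1.7-fold lower number from compound 1 to compound 3 (0.24 log units; within the scatter), and a 3.8-fold lower number from compound 2 to compound 3 (0.58 log units; beyond the scatter). Among the measured compounds shown here, these steps span a narrow band, and the replacement of fluoro by nitro is the one that moves the number beyond the scatter from compound 1. The change to compound 4 keeps a halogen on that ring, so a small step is expected: the estimated step of a 1.1-fold lower number from compound 1 to compound 4 (0.02 log units; within the scatter) is expected to stay within the scatter. For compound 4 the estimated value in this assay is 12000 nM, with an expected range from 5000 nM to 30000 nM.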

Compound 4, half-maximal inhibitory concentration: 40400 nM
Compound 4: the middle estimate sits 3.4-fold (0.53 log units) below what was measured, and the stated range ends below it.
By their numbers in this assay, from the lowest: compounds 3 and 1 (each within the scatter of the next); then compounds 2 and 4 (each within the scatter of the next).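

In this assay, 4-chlorophenyl in place of 3-fluorophenyl on the amide-type nitrogen gives a 3.2-fold higher number from compound 1 to compound 4 (0.50 log units; beyond the scatter) and so shows that keeping a halogen on this ring does not by itself hold the number near that of compound 1. Set against the other two groups at this position, the same ring gives a 5.5-fold higher number from compound 3 to compound 4 (0.74 log units; beyond the scatter) and a 1.4-fold higher number from compound 2 to compound 4 (0.16 log units; within the scatter) and thus places compound 4 level with the nitro-bearing compound 2, while the (vinylcarbonyl)amino-bearing compound 3 keeps a clearly lower number than either. Nothing at hand explains why this exchange moves the number as it does.

The halogen and its place on the ring change together in this one step, and no compound shown separates the two, so it stays open which of them carries the change. From the compounds shown here alone, it also stays open how plain phenyl on that nitrogen, a bromo or methoxy group on the ring, or an amine or a carboxylic acid there would read against these four numbers.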